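The compounds below may be only part of what the source reports. "The series", "measured", "known", "first", "only" and "open" are said of these compounds alone.

Compound 1 `COc1ccc(-c2cc(/C=C/C(=O)c3ccc(N)cc3)[nH]n2)cc1`: 100%
Compound 2 `COc1cc(-c2cc(/C=C/C(=O)c3ccc(Cl)c(Cl)c3)[nH]n2)cc(OC)c1OC`: 95%
Compound 3 `COc1ccc(C(=O)/C=C/c2cc(-c3cc(OC)c(OC)c(OC)c3)n[nH]2)cc1`: 90%

In a functional assay on RPMI-8226 cells (Homo sapiens) for cytotoxicity, read by sulforhodamine B assay, with a stated time of 48 h, tested at 0.1 uM (a lower number here means a stronger effect, a higher number a weaker effect of the compound at the concentration tested), compound 1 gives 100%, a number that lies within the scatter of compound 2 at 95% and of compound 3 at 90%; none of the three can be set apart from the others. Compound 4 `COc1ccc(-c2cc(/C=C/C(=O)c3ccc(N)cc3)[nH]n2)cc1OC` differs from compound 1 by methoxy in place of hydrogen on an aromatic carbon. Among the measured compounds shown here, the only measured step, a number 5 percentage points lower from compound 2 to compound 3 (within the scatter), concerns the aryl group on the carbonyl carbon and not the ring that is altered here, so it bears on this change only loosely; the three measured numbers give no sign that any change among them moves the read-out. Compound 4 is therefore expected to give 97% (range 85% to 105%). The expected step of a number 3 percentage points lower from compound 1 to compound 4 (within the scatter) is expected to stay within the scatter.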

Compound 4, a percentage reported as activity, at one concentration (the size of the read-out at that concentration, not a potency): 96%
Beside the measured number, compound 4's estimate is 1 percentage points above it; the range from low to high includes it.
By their numbers in this assay, from the lowest: compounds 3, 2, 4 and 1 (each within the scatter of the next).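

In this assay, adding methoxy in place of hydrogen on an aromatic carbon, ortho to a methoxy group and meta to a large group, gives a number 4 percentage points lower from compound 1 to compound 4 (within the scatter). Among the compounds shown here, this is the first direct reading of this position, and at this single concentration the added methoxy does not set compound 4 apart from compound 1. No supporting evidence bears on this result.

As far as these compounds go, it remains open whether a larger ether such as benzyloxy, an amine or a carboxylic acid at this position would also stay within the scatter. A single concentration also leaves any difference in potency between compound 1 and compound 4 unresolved.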